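Methyl in place of fluoro: expectation for compound 3

A few compounds are considered here, and "the series" means these few. Any claim that something is new, unique, unknown or untested is made for them only; others in the source may bear on it.

Compound 1 `COc1cc(/C=C/C(=O)OCCSc2nc(-c3ccc(S(C)(=O)=O)cc3)n(-c3ccc(Br)cc3)n2)ccc1OC(C)=O` and compound 2 `COc1cc(/C=C/C(=O)OCCSc2nc(-c3ccc(S(C)(=O)=O)cc3)n(-c3ccc(F)cc3)n2)ccc1OC(C)=O` share one core and differ only by fluoro in place of bromo on an aromatic carbon. In a functional assay on A549 cells (Homo sapiens) for antiproliferative activity, read by MTT assay, with a stated time of 72 h (a lower number here means a stronger inhibitor, a higher number a weaker inhibitor), compound 1 gives 11100 nM and compound 2 gives 9610 nM; the step of a 1.2-fold lower number from compound 1 to compound 2 (0.06 log units; within the scatter) is within the scatter, so compound 2 holds the lower of the two numbers without being separable from compound 1. Compound 3 `COc1cc(/C=C/C(=O)OCCSc2nc(-c3ccc(S(C)(=O)=O)cc3)n(-c3ccc(C)cc3)n2)ccc1OC(C)=O` carries the change (methyl in place of fluoro on an aromatic carbon), at the place para to a large group on a six-membered aromatic ring of carbon only. Within the data shown here, no measured step covers methyl against fluoro; the only step at this place, a 1.2-fold lower number from compound 1 to compound 2 (0.06 log units; within the scatter), was within the scatter, which gives no ground for a step beyond the scatter in this assay here either. Compound 3 is therefore expected to give 10000 nM in this assay, between 4000 nM and 25000 nM. The implied step a 1.0-fold higher number from compound 2 to compound 3 (0.02 log units; within the scatter) is expected to stay within the scatter.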

Compound 3, half-maximal inhibitory concentration: 15000 nM
Beside the measured number, compound 3's estimate is 1.5-fold (0.18 log units) below it, within the range that was stated.
By their numbers in this assay, from the lowest: compounds 2, 1 and 3 (each within the scatter of the next).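

In this assay the step of a 1.6-fold higher number from compound 2 to compound 3 (0.19 log units; within the scatter) and the step of a 1.4-fold higher number from compound 1 to compound 3 (0.13 log units; within the scatter) both lie within the scatter, so methyl, para to a large group on the six-membered aromatic ring of carbon only, cannot be separated from fluoro or bromo. The earlier pair compared two halogens only; this place now also covers a carbon substituent, and all three compounds remain within the scatter of one another in this read-out. No evidence bearing on this result is available.

From the compounds shown here alone, it remains open whether an amine, a carboxylic acid or a longer chain such as butyl at this place would give a step beyond the scatter. The compounds shown also leave open whether changes elsewhere on the shared core would move these numbers more than changes at this place.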